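Swapping the aryl ether in a cytotoxicity series

The source may hold more compounds than are shown below. What is called first, only, known or untested is meant among the compounds shown, and "the series" means these compounds.

Measured compounds:
- compound 1 `Cc1cc(C#N)cc(C)c1Oc1nc(Nc2ccc(C#N)cc2)nc2ccccc12`: 203000 nM
- compound 2 `Cc1cccc(C)c1Oc1nc(Nc2ccc(C#N)cc2)nc2ccccc12`: 35000 nM
- compound 3 `COc1ccccc1Oc1nc(Nc2ccc(C#N)cc2)nc2ccccc12`: 150000 nM

In an ADME assay on MT4 cells (Homo sapiens) for cytotoxicity, read by MTT assay, with a stated time of 4 days (a higher number here means that more compound is tolerated, a lower number that less compound is tolerated), compound 1 gives the highest of the three numbers. Compound 3 sits within the scatter of it, a 1.4-fold lower number from compound 1 to compound 3 (0.13 log units; within the scatter), while compound 2 lies clearly lower, a 5.8-fold lower number from compound 1 to compound 2 (0.76 log units; beyond the scatter).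

Compound 4 `N#Cc1ccc(Nc2nc(Oc3ccc(Br)cc3)c3ccccc3n2)cc1` has not been measured. It differs from compound 1 in one place: 4-bromophenyl in place of 4-cyano-2,6-dimethylphenyl on an oxygen on an aromatic ring.

Within the data shown here, two measured steps bear on this. Removing the cyano group alone, a 5.8-fold lower number from compound 1 to compound 2 (0.76 log units; beyond the scatter), cut the tolerated concentration by a modest but clear amount. Replacing the whole group with 2-methoxyphenyl, a 1.4-fold lower number from compound 1 to compound 3 (0.13 log units; within the scatter), changed little, and between those two the step of a 4.3-fold higher number from compound 2 to compound 3 (0.63 log units; beyond the scatter) again shows a modest shift. Compound 4 loses the cyano group and both methyls and gains a bromine, a change for which the measured set has no exact match, so the expectation leans on the loss of the cyano group.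

Compound 4 is therefore expected to be tolerated less well than compound 1, estimated as a 4.1-fold lower number from compound 1 to compound 4 (0.61 log units; beyond the scatter). The estimate for compound 4 is 50000 nM, with a likely range from 15000 nM to 160000 nM.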

Compound 4, half-maximal cytotoxic concentration: 215000 nM
For compound 4 the middle estimate is 4.3-fold (0.63 log units) below the measured one; measured number above the stated range.
By their numbers in this assay, from the lowest: compound 2; then compounds 3, 1 and 4 (each within the scatter of the next).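

In this assay, compound 4 stays level with the two highest compounds, a 1.1-fold higher number from compound 1 to compound 4 (0.02 log units; within the scatter) and a 1.4-fold higher number from compound 3 to compound 4 (0.16 log units; within the scatter), so on this oxygen a ring without a cyano group can still reach the top of the series, and the 4-cyano-2,6-dimethylphenyl group is not required for it. Compound 2 alone stands apart, a 6.1-fold higher number from compound 2 to compound 4 (0.79 log units; beyond the scatter), which means that losing the cyano group does not by itself give the lower number. No measurement here explains why compound 2 differs.

As far as these compounds go, the effects of the bromine and of losing both methyls arrive together in compound 4, so their separate shares stay open. Also open, from the compounds shown here alone, is how a ring carrying an amine or a carboxylic acid on this oxygen would behave, or a longer chain in place of the ring.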